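Chlorophenyl to Aminophenyl on a Shared Core

This account rests on a few compounds, and the source may have more. Where it says the series, first, only, none or still open, it means among the compounds named here.

Compound 1 `COc1cc(-c2cccc3nc(-c4cccc(F)c4)oc23)cc(OC)c1OC` and compound 2 `COc1cc(-c2cccc3nc(-c4cccc(Cl)c4)oc23)cc(OC)c1OC` share one core and differ only in the halogen on the pendant phenyl ring. In a functional assay on MCF7 cells (Homo sapiens) for antiproliferative activity, read by MTT assay, with a stated time of 48 h (on this read-out lower numbers stand for stronger inhibition and higher numbers for weaker inhibition), compound 1 reaches only the limit of the assay, > 25000 nM. In this assay compound 2 likewise reaches only a limit, > 25000 nM. The step that the two limits leave unreadable from compound 1 to compound 2 therefore cannot be read, since (the limit of > 25000 nM in this assay, at which 2 of the 2 values shown sit). Compound 2 thus stands at the limit, with no number of its own. Compound 3 `COc1cc(-c2cccc3nc(-c4ccc(N)cc4)oc23)cc(OC)c1OC` carries 4-aminophenyl in place of 3-chlorophenyl on an aromatic carbon. For the measured compounds named here, no measured step bears on this change: the only step on record is unreadable, so it offers no size and no direction to expect in this assay. The estimate for compound 3 is accordingly 20000 nM, within 3000 nM to 100000 nM, with a real chance that only a limit is reported again. The expected step is an at least 1.2-fold lower number from compound 2 to compound 3 (0.09 log units; that floor lies within the scatter).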

Compound 3, half-maximal inhibitory concentration: > 25000 nM
Compound 3: no number, only a limit; the forecaster's own chance of this, stated with the estimate: 60%; middle value at least 1.2-fold (0.09 log units) away from the limit.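

Compound 3, like compound 1 and compound 2, gives only a limit in this assay, so no step among these three compounds can be read: the limit of > 25000 nM in this assay, at which 3 of the 3 values shown sit.

The compounds shown leave open how these three rank against one another and whether any change on the shared core would give a readable number.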